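The compounds below may be only part of what the source reports. "The series", "measured", "known", "first", "only" and "open" are said of these compounds alone.

Values in a functional assay on A549 cells (Homo sapiens) for antiproliferative activity, read by MTT assay, with a stated time of 72 h (a higher number here means a weaker inhibitor, a lower number a stronger inhibitor), so far:

Compound 1 `Cc1nc(C(=O)Nc2ccc(Cl)c(-c3nnc4c(Cl)cccn34)c2)cs1` gives > 100000 nM, a limit of the assay.
Compound 2 `O=C(Nc1ccc(Cl)c(-c2nnc3c(Cl)cccn23)c1)c1cccnc1` gives > 100000 nM, a limit of the assay.
Compound 3 `O=C(Nc1ccc(Cl)c(-c2nnc3c(Cl)cccn23)c1)c1ccc(C(F)(F)F)cc1F` gives > 100000 nM, a limit of the assay.

For the measured compounds named here, compound 2 thus stands where every measured compound of the shared core stands, at the limit; the one neighbouring step, from compound 1 to compound 2 a step that the two limits leave unreadable from compound 1 to compound 2, cannot be sized because of the limit of > 100000 nM in this assay, at which 3 of the 3 values shown sit. Compound 4 `O=C(Nc1ccc(Cl)c(-c2nnc3c(Cl)cccn23)c1)c1ccc(Cl)cc1Cl` differs from compound 2 by 2,4-dichlorophenyl in place of pyridin-3-yl on a carbonyl carbon. Going by the values given here, no measured step reads on this change, and the three limits give no direction beyond the scatter. Compound 4 is therefore expected to sit at the limit as well, estimated at 100000 nM (range 40000 nM to 300000 nM), a step of a number no higher from compound 2 to compound 4 (the limit leaves the size open) that is expected to be unreadable.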

Compound 4, half-maximal inhibitory concentration: 61300 nM
Compound 4: middle estimate off by 1.6-fold (0.21 log units), on the high side; the measured number falls inside the stated range.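

In this assay, for the compounds shown here, compound 4 gives 61300 nM, the only value shown that is not a limit, so this position on the carbonyl carbon can carry a group that gives a readable number. 2,4-Dichlorophenyl gives an at least 1.6-fold lower number from compound 2 to compound 4 (0.21 log units; that floor lies within the scatter) and an at least 1.6-fold lower number from compound 1 to compound 4 (0.21 log units; that floor lies within the scatter), so neither step is established beyond the scatter, and their true sizes stay open. The other steps cannot be read because of the assay limit: the limit of > 100000 nM in this assay, at which 3 of the 4 values shown sit.

As far as these compounds go, whether either chlorine alone gives a readable number remains open. Also open, from the compounds shown here alone, is how a carboxylic acid or an amine on this phenyl ring would read in this assay.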